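From Methoxy to Propyl in a Cell Toxicity Test

This account rests on a few compounds, and the source may have more. Where it says the series, first, only, none or still open, it means among the compounds named here.

In an ADME assay on J774 cells (Mus musculus) for cytotoxicity (a higher number here means that more compound is needed for the effect, a lower number that less compound is needed), compound 1 `COC(=O)c1c[nH]c2cc(OCCOc3ccccc3)c(OC)cc2c1=O` gives > 20000 nM, which is a limit of the assay and not a number. Going by the values given here, compound 2 `COC(=O)c1c[nH]c2ccc(Cl)cc2c1=O`, the only other compound measured, gives > 20000 nM, which is also a limit. All that the data show so far is the limit of > 20000 nM in this assay, at which 2 of the 2 values shown sit.

Compound 3 `CCCc1cc2c(=O)c(C(=O)OC)c[nH]c2cc1OCCOc1ccccc1` keeps the core and the side chain of compound 1 but carries propyl in place of methoxy on an aromatic carbon, ortho to a large group: propyl in place of methoxy on an aromatic carbon. Among the compounds with values here, no pair of measured compounds shows what such a swap does in this assay, so there is no direct precedent for it.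

The expected a number no higher from compound 1 to compound 3 (the limit leaves the size open) is no larger than the usual scatter, with neither direction favoured. That expectation rests on compound 1, whose reading of > 20000 nM is a limit. For compound 3 the estimated value is 20000 nM, with an expected range from 9000 nM to 40000 nM.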

Compound 3, half-maximal effective concentration: > 20000 nM
Compound 3: a limit, no number; the forecaster's own chance of this, stated with the estimate: 75%; the middle value sits exactly at the limit.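

In this assay compound 3 gives > 20000 nM, which is a limit of the assay and not a number. Going by these compounds alone, compound 1 also stands at a limit, and no step between compound 1 and compound 3 can be read. The compounds shown leave open what concentration any of them needs for the effect, and whether propyl in place of methoxy alters it: the limit of > 20000 nM in this assay, at which 3 of the 3 values shown sit.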